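Series notes: amine tail change on compound 2

This account rests on a few compounds, and the source may have more. Where it says the series, first, only, none or still open, it means among the compounds named here.

The three measured compounds share one core and differ only in the aryl on the triazole nitrogen. Compound 1 `COc1cc2c(Oc3ccc(NC(=O)c4cn(-c5ccccc5Cl)nn4)cc3F)ccnc2cc1OCCCN1CCCC1` gives 190 nM in a functional assay on NCI-H460 cells (Homo sapiens) for cytotoxicity, read by MTT assay, with a stated time of 72 h; on this read-out lower numbers stand for stronger inhibition and higher numbers for weaker inhibition; compound 3 `COc1cc2c(Oc3ccc(NC(=O)c4cn(-c5ccc(Br)cc5)nn4)cc3F)ccnc2cc1OCCCN1CCCC1` gives 200 nM; compound 2 `COc1cc2c(Oc3ccc(NC(=O)c4cn(-c5ccccc5C)nn4)cc3F)ccnc2cc1OCCCN1CCCC1` gives 1260 nM, the highest number of the three, with a 6.6-fold higher number from compound 1 to compound 2 (0.82 log units; beyond the scatter) and a 6.3-fold lower number from compound 2 to compound 3 (0.80 log units; beyond the scatter) both beyond the scatter, while a 1.1-fold higher number from compound 1 to compound 3 (0.02 log units; within the scatter) stays within it.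

Compound 4 `COc1cc2c(Oc3ccc(NC(=O)c4cn(-c5ccccc5C)nn4)cc3F)ccnc2cc1OCCCN1CCC(C)CC1` is compound 2 with one change at the far end of the molecule: 4-methylpiperidin-1-yl in place of pyrrolidin-1-yl on a saturated chain carbon, three bonds along the chain from an oxygen on an aromatic ring. For the measured compounds named here, none of the measured steps touches this position; all three concern the aryl on the triazole nitrogen, and the amine tail is the same in every measured compound. There is therefore no basis for expecting a step beyond the scatter in this assay in either direction, only a wide band around the parent value.

Compound 4 is estimated at 1260 nM, within a range of 450 nM to 3500 nM, meaning an expected step of no change at the digits printed from compound 2 to compound 4 (within the scatter).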

Compound 4, half-maximal inhibitory concentration: 2730 nM
Estimate against measurement, compound 4: 2.2-fold (0.34 log units) below; measured number inside the range.
By their numbers in this assay, from the lowest: compounds 1 and 3 (each within the scatter of the next); then compound 2; then compound 4.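

The amine tail is not a silent position: in this assay the change from 3-(pyrrolidin-1-yl)propyl to 3-(4-methylpiperidin-1-yl)propyl gives a 2.2-fold higher number from compound 2 to compound 4 (0.34 log units; beyond the scatter) on the 2-methylphenyl background, the first measured step outside the aryl on the triazole nitrogen. Ring size and the added methyl change together here, from a five-membered to a six-membered ring, while the counts of hydrogen-bond donors and acceptors stay the same, so this one step cannot assign the shift to either feature. No measurement at hand accounts for the step.

On these data alone, whether piperidin-1-yl without the methyl, or morpholin-4-yl, would separate ring size from substitution stays open. Also open, as far as these compounds go, is whether the same tail change carries over to the 2-chlorophenyl of compound 1 or the 4-bromophenyl of compound 3.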